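The compounds below may be only part of what the source reports. "The series", "measured", "known", "first", "only" and "open" are said of these compounds alone.

Measured compounds:
compound 1 `CCN(Cc1ccncc1)c1cccc(C(=O)N2CCc3ccc(OS(N)(=O)=O)cc3C2)c1` gives 33.3% in an assay on HEK293 cells for inhibition of Steryl-sulfatase (Homo sapiens), tested at 0.1 uM; on this read-out lower numbers stand for a weaker effect and higher numbers for a stronger effect at the one concentration tested;
compound 2 `CCN(Cc1cccc(Br)c1)c1cccc(C(=O)N2CCc3ccc(OS(N)(=O)=O)cc3C2)c1` gives 20.9% in this assay.

Compound 2 stands lowest of the two; its nearest neighbour is compound 1, and the step of a number 12.4 percentage points lower from compound 1 to compound 2 (beyond the scatter) is beyond the scatter. Compound 3 `CCN(Cc1ccccn1)c1cccc(C(=O)N2CCc3ccc(OS(N)(=O)=O)cc3C2)c1` is not yet measured. Its change from compound 2 is pyridin-2-yl in place of 3-bromophenyl on a saturated chain carbon bound to a nitrogen on an aromatic ring. Within the data shown here, the only step that bears on it is a number 12.4 percentage points lower from compound 1 to compound 2 (beyond the scatter), which went from a pyridinyl to the 3-bromophenyl with a modest loss; compound 3 returns to a pyridinyl, so a modest gain beyond the scatter is expected, a number 9.1 percentage points higher from compound 2 to compound 3 (within the scatter). Compound 3 is estimated at 30%, range 15% to 45%.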

Compound 3, a percentage reported as inhibition, at one concentration (the size of the read-out at that concentration, not a potency): 6.5%
Compound 3: the middle estimate sits 23.5 percentage points above what was measured, outside the stated range (below it).
By their numbers in this assay, from the lowest: compound 3; then compound 2; then compound 1.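

In this assay, swapping pyridin-4-yl for pyridin-2-yl on the saturated chain carbon gives a number 26.8 percentage points lower from compound 1 to compound 3 (beyond the scatter), so the effect does not follow the presence of a pyridinyl as such but differs between these two pyridine isomers. Pyridin-2-yl also ranks under 3-bromophenyl, with a number 14.4 percentage points lower from compound 2 to compound 3 (beyond the scatter), so the two pyridinyl groups fall on either side of the 3-bromophenyl. Nothing available explains this order. Still open, on these data alone, is where pyridin-3-yl or unsubstituted phenyl would stand at this place, and whether a longer chain in place of the ethyl would preserve the order.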